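Swapping Methyl for Fluoro on a Growth Inhibition Scaffold

The source may hold more compounds than are shown below. What is called first, only, known or untested is meant among the compounds shown, and "the series" means these compounds.

Of the compounds shown here, three have so far been measured in a functional assay on HeLa cells (Homo sapiens) for inhibition, read by CCK-8 assay, with a stated time of 72 h, tested at 2 uM; a lower number here means less inhibition of growth, a higher number more inhibition of growth at the concentration tested. Compound 1 `Cc1ccc(SCc2ccc(/C=C/C(=O)Nc3ccccc3N)cc2)cc1` gives 25.5% in this assay. Compound 2 `Nc1ccccc1NC(=O)c1ccc(CSc2nccc(C(F)(F)F)n2)cc1` gives 68.3%, and compound 3 `Nc1ccccc1NC(=O)c1ccc(CSc2ccc(Br)cc2)cc1` gives 18.8%. Among these three numbers compound 1 stands second highest: its value and that of compound 3 lie within the usual scatter of each other, so no order between them can be claimed, while compound 2 lies beyond that scatter above compound 1.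

Compound 4 `Nc1ccccc1NC(=O)/C=C/c1ccc(CSc2ccc(F)cc2)cc1` has not yet been measured. It differs from compound 1 in a single place: fluoro in place of methyl on an aromatic carbon. Within the data shown here, no measured pair in this set shows that same change, so nothing here tells how large its effect is, and the only anchor is the number for compound 1. The expected step is therefore small, a number 0.5 percentage points higher from compound 1 to compound 4 (within the scatter), with none expected beyond the scatter in either direction. Compound 4 is thus estimated to give 26%, in a range from 10% to 45%.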

Compound 4, percent growth inhibition at one concentration: 7.09%
Beside the measured number, compound 4's estimate is 18.9 percentage points above it, outside the stated range (below it).
By their numbers in this assay, from the lowest: compound 4; then compounds 3 and 1 (each within the scatter of the next); then compound 2.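

The swap of methyl for fluoro at this place is not a silent one: in this assay, the change reads a number 18.4 percentage points lower from compound 1 to compound 4 (beyond the scatter). This shows that the aromatic carbon para to a large group can affect the read-out, even though one heavy atom simply replaces another and the counts of rings, hydrogen-bond donors, hydrogen-bond acceptors and net charge stay the same. No available evidence bears on what lies behind this drop.

Among these compounds, with only two groups at this carbon, it remains open whether losing the methyl or gaining the fluoro matters more. A plain hydrogen, a methoxy group or an amine at the same place would help separate these two readings, and would show whether the read-out follows any trend across groups.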